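The source may hold more compounds than are shown below. What is called first, only, known or untested is meant among the compounds shown, and "the series" means these compounds.

Measured in a functional assay on MCF7 cells (Homo sapiens) for antiproliferative activity, read by MTT assay, with a stated time of 24 h; on this read-out higher numbers stand for weaker inhibition and lower numbers for stronger inhibition:
- compound 1 `COc1ccc(S(=O)(=O)n2c(-c3cn(-c4ccccc4)nc3-c3ccc(F)cc3)nc3ccccc32)cc1`: 530 nM
- compound 2 `O=S(=O)(c1ccc(Cl)cc1)n1c(-c2cn(-c3ccccc3)nc2-c2ccc(F)cc2)nc2ccccc21`: 4960 nM
- compound 3 `O=S(=O)(c1ccc(C(F)(F)F)cc1)n1c(-c2cn(-c3ccccc3)nc2-c2ccc(F)cc2)nc2ccccc21`: 1580 nM

Compound 3, at 1580 nM, holds the second highest of the three numbers. The next change leads to compound 4 `O=S(=O)(c1ccc(C(F)(F)F)cc1)n1c(-c2cn(-c3ccccc3)nc2-c2ccc(C(F)(F)F)cc2)nc2ccccc21`, with trifluoromethyl in place of fluoro on an aromatic carbon.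

For the measured compounds named here, no measured step covers this aromatic carbon, so the evidence is indirect. All three steps were made at a different aromatic carbon. Trifluoromethyl in place of methoxy gave a 3.0-fold higher number from compound 1 to compound 3 (0.47 log units; beyond the scatter). Trifluoromethyl in place of chloro gave a 3.1-fold lower number from compound 2 to compound 3 (0.50 log units; beyond the scatter). Chloro in place of methoxy gave a 9.4-fold higher number from compound 1 to compound 2 (0.97 log units; beyond the scatter). These steps are modest and run in both directions, so they fix no direction for the new change. A small step in this assay is expected, leaning slightly towards a higher number, and it may not clear the scatter. The expected step is a 1.3-fold higher number from compound 3 to compound 4 (0.10 log units; within the scatter). The estimated value for compound 4 is 2000 nM, with an expected range of 650 nM to 6500 nM.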

Compound 4, half-maximal inhibitory concentration: 1240 nM
Compound 4: middle estimate off by 1.6-fold (0.21 log units), on the high side; measured number inside the range.
By their numbers in this assay, from the lowest: compound 1; then compounds 4 and 3 (each within the scatter of the next); then compound 2.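

For the compounds shown here, this is the first reading at this aromatic carbon: in this assay, the change from 4-fluorophenyl to 4-(trifluoromethyl)phenyl gives a 1.3-fold lower number from compound 3 to compound 4 (0.11 log units; within the scatter). The three earlier steps, all at a different aromatic carbon, lay beyond the scatter, whereas this exchange leaves the number unresolved from that of its parent, so this single pair shows no readable response to this change at this position. No measured evidence accounts for this result.

On these data alone, it remains open whether this position stays as unresponsive with a group of a different kind, such as an amine or a carboxylic acid, in place of fluoro. Also open, as far as these compounds go, is whether the same exchange would read alike with methoxy or chloro, rather than trifluoromethyl, at the other substituted aromatic carbon.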